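Series notes: oxolane ring variation on the shared core

The source may hold more compounds than are shown below. What is called first, only, known or untested is meant among the compounds shown, and "the series" means these compounds.

Measured so far: compound 1 `COc1cc(-c2cnn3cc(OC)c(-c4cnn(C)c4)nc23)ccn1` gives 530 nM; compound 2 `COc1cc(-c2cnn3cc(OC)c(C(C)(C)O)nc23)ccn1` gives 2700 nM; compound 3 `COc1cc(-c2cnn3cc(OC)c(C4CCOC4)nc23)ccn1` gives 1900 nM, all in an assay on isolated protein for inhibition of activin receptor type-2A (Homo sapiens), read by 33P incorporation, with a stated time of 20 min, in the presence of a further agent that is not named here; on this read-out lower numbers stand for stronger inhibition and higher numbers for weaker inhibition.

Compound 3 stands second highest of the three numbers; its nearest neighbour is compound 2 a 1.4-fold lower number from compound 2 to compound 3 (0.15 log units; within the scatter), and its furthest is compound 1 a 3.6-fold higher number from compound 1 to compound 3 (0.55 log units; beyond the scatter). Compound 4 `COc1cc(-c2cnn3cc(OC)c([C@@H]4COC(C)(C)C4)nc23)ccn1` differs from compound 3 by a group of 7 heavy atoms (6 carbon, 1 oxygen; one five-membered non-aromatic ring with 1 hetero atom) in place of a group of 5 heavy atoms (4 carbon, 1 oxygen; one five-membered non-aromatic ring with 1 hetero atom), on an aromatic carbon. For the measured compounds named here, no measured step covers this change; the only step touching the oxolane, from compound 2 to compound 3, stayed within the scatter, while the two steps from compound 1 were modest. Adding two methyl groups to the ring is therefore expected to shift the number little, and for compound 4 the expected step is a 1.3-fold lower number from compound 3 to compound 4 (0.10 log units; within the scatter), giving an estimate of 1500 nM with a range of 600 nM to 4000 nM.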

Compound 4, half-maximal inhibitory concentration: 5300 nM
Compound 4: the middle estimate sits 3.5-fold (0.55 log units) below what was measured; the measured number lies above the stated range.
By their numbers in this assay, from the lowest: compound 1; then compounds 3, 2 and 4 (each within the scatter of the next, the first and the last beyond it).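

For the compounds shown here, two methyl groups on the oxolane ring do register at this position (a 2.8-fold higher number from compound 3 to compound 4 (0.45 log units; beyond the scatter)), which the earlier compounds could not show. Against the open-chain 1-hydroxy-1-methylethyl group the new ring remains close (a 2.0-fold higher number from compound 2 to compound 4 (0.29 log units; within the scatter)), while the gap to the 1-methyl-1H-pyrazol-4-yl group widens (a 10-fold higher number from compound 1 to compound 4 (1.00 log units; beyond the scatter)), leaving that aromatic ring with the lowest number of the four. No measurement at hand accounts for the step.

Open, as far as these compounds go, is whether the opposite stereoisomer of compound 4 gives a similar number. Also open, from the compounds shown here alone, is whether an amine or a carboxylic acid on the ring would be tolerated here.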